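A few compounds are considered here, and "the series" means these few. Any claim that something is new, unique, unknown or untested is made for them only; others in the source may bear on it.

Measured compounds:
- compound 1, `COc1ccc(OC)c(/C=C/c2nnc(Nc3ccc(Cl)cc3)o2)c1`; in a functional assay on CAKI-1 cells (Homo sapiens) for antiproliferative activity, read by sulforhodamine B assay, with a stated time of 48 h (a higher number here means a weaker inhibitor of growth, a lower number a stronger inhibitor of growth), compound 1 gives 6020 nM
- compound 2, `COc1ccc(OC)c(/C=C/C(=O)N/N=C/c2ccc(Cl)cc2)c1`; in this assay compound 2 gives 87.9 nM

Of these two numbers, compound 2 has the lower one, and the gap between compound 2 and compound 1 lies well beyond the usual scatter of repeated measurements. Compound 3, `COc1ccc(OC)c(/C=C/C(=O)N/N=C/c2ccccc2)c1`, has not yet been measured in this assay. It differs from compound 2 in one place: hydrogen in place of chloro on an aromatic carbon. Going by the values given here, no step between two measured compounds matches this change, so there is nothing in the data that shows how large the effect should be. Compound 3 is expected to give a somewhat higher number than compound 2, with a modest step of a 1.7-fold higher number from compound 2 to compound 3 (0.23 log units; within the scatter) that may not exceed the scatter. Because compound 2 gives 87.9 nM, compound 3 is estimated at 150 nM, with a range from 50 nM to 450 nM.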

Compound 3, concentration for 50% growth inhibition: 443 nM
Beside the measured number, compound 3's estimate is 3.0-fold (0.47 log units) below it; low and high end bracket the measured number.
By their numbers in this assay, from the lowest: compound 2; then compound 3; then compound 1.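

In this assay, this position on the aromatic ring is not indifferent to what it carries: the change from 4-chlorophenyl to phenyl gives a 5.0-fold higher number from compound 2 to compound 3 (0.70 log units; beyond the scatter), so the chloro group goes with the stronger inhibition of growth in this pair. The earlier compounds shown here could not show this, since compound 1 and compound 2 differ in more than one place and no single change had yet been read. Nothing measured here explains why this one atom counts for so much.

On these data alone, whether a fluoro, a methoxy, an amine or a carboxylic acid at the same position would give a number nearer that of compound 2 or that of compound 3 stays open. As far as these compounds go, it also stays open whether removing the chloro group from compound 1 would give a step of similar size on its core.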